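From diethylamino to dipropylamino on the shared core

The source may report more compounds than this note shows. Statements on the series, on what has been measured and on what is new or still open speak of the compounds shown alone.

For the measured compounds named here, in an ADME assay on A549 cells (Homo sapiens) for cytotoxicity, read by resazurin assay, with a stated time of 48 h (a higher number here means that more compound is tolerated, a lower number that less compound is tolerated), compound 1 `O=C(Nc1ccc(NCC2CC2)cc1Cl)c1cc(Cl)ccc1O` gives 14400 nM, while compound 2 `CCN(CC)c1ccc(NC(=O)c2cc(Cl)ccc2O)c(Cl)c1` gives 55500 nM, the higher of the only two numbers measured so far. Compound 3 `CCCN(CCC)c1ccc(NC(=O)c2cc(Cl)ccc2O)c(Cl)c1` keeps the core of compound 2 but carries dipropylamino in place of diethylamino on an aromatic carbon. Going by the values given here, only one measured step comes close to this change: putting diethylamino in place of (cyclopropylmethyl)amino gave a 3.9-fold higher number from compound 1 to compound 2 (0.59 log units; beyond the scatter). That modest step involved a different pair of groups, and a single comparison sets no trend. No direction can therefore be read for this assay, and no change beyond the usual scatter is expected. The estimated step is a 1.2-fold lower number from compound 2 to compound 3 (0.09 log units; within the scatter). For compound 3, the expected value is 45000 nM, with an estimated range of 18000 nM to 100000 nM.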

Compound 3, half-maximal cytotoxic concentration: 10700 nM
Compound 3: middle estimate off by 4.2-fold (0.62 log units), on the high side; measured number below the stated range.
By their numbers in this assay, from the lowest: compounds 3 and 1 (each within the scatter of the next); then compound 2.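

Swapping diethylamino for dipropylamino at this position is not a neutral change in this assay: the measured result is a 5.2-fold lower number from compound 2 to compound 3 (0.71 log units; beyond the scatter), so a modest difference in the amino group can move this number beyond the scatter. The other new comparison gives a 1.3-fold lower number from compound 1 to compound 3 (0.13 log units; within the scatter), which is within the scatter, so dipropylamino and (cyclopropylmethyl)amino cannot be told apart here, and only compound 2, with diethylamino, stands clear of the other two. The data shown offer no measured explanation for this difference.

On these data alone, a single step from diethylamino to dipropylamino sets no trend, so it remains open whether a longer chain such as dibutylamino would continue the same direction. As far as these compounds go, how a ring-closed amine such as morpholine or pyrrolidine would read at this position also remains open.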